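A few compounds are considered here, and "the series" means these few. Any claim that something is new, unique, unknown or untested is made for them only; others in the source may bear on it.

Measured so far in an ADME assay on CHO-K1 cells (Cricetulus griseus) for cytotoxicity, read by MTT assay, with a stated time of 24 h; a higher number here means a weaker inhibitor, a lower number a stronger inhibitor:
compound 1, `O=[N+]([O-])c1cc(-c2nnn(Cc3ccccc3)n2)cc([N+](=O)[O-])c1` — 150000 nM
compound 2, `O=[N+]([O-])c1cc(-c2nnn(Cc3ccc(Br)cc3)n2)cc([N+](=O)[O-])c1` — 55000 nM

Among these two, compound 2 holds the lower number in this assay, and the step of a 2.7-fold lower number from compound 1 to compound 2 (0.44 log units; beyond the scatter) sets it apart from compound 1 by more than the usual scatter. Compound 3, `O=[N+]([O-])c1cc(-c2nnn(Cc3ccccc3F)n2)cc([N+](=O)[O-])c1`, differs from compound 2 in one place: 2-fluorophenyl in place of 4-bromophenyl on a saturated chain carbon bound to an aromatic nitrogen. For the measured compounds named here, only one measured step bears on this change, a 2.7-fold lower number from compound 1 to compound 2 (0.44 log units; beyond the scatter), and it covers just the bromine that compound 3 gives up; no measured pair speaks to the fluorine that enters. Because the bromine's arrival brought a 2.7-fold lower number from compound 1 to compound 2 (0.44 log units; beyond the scatter), its removal is expected to undo much of that, with the fluorine left as an unknown, so a modest rise in the number is expected, a 1.8-fold higher number from compound 2 to compound 3 (0.26 log units; within the scatter). Compound 3 is therefore estimated at 100000 nM in this assay, within a range of 45000 nM to 220000 nM.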

Compound 3, half-maximal inhibitory concentration: > 200000 nM
Compound 3: only a limit was reported; the forecaster's own chance of this, stated with the estimate: 15%; middle value at least 2.0-fold (0.30 log units) from the limit.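

Compound 3 gave only a limit in this assay, not a number: the limit of > 200000 nM in this assay, at which 1 of the 3 values shown sits. With that floor, 2-fluorophenyl in place of 4-bromophenyl on a saturated chain carbon bound to an aromatic nitrogen gives an at least 3.6-fold higher number from compound 2 to compound 3 (0.56 log units; beyond the scatter), so the lower number seen with the 4-bromophenyl group does not carry over to this other halogen-bearing ring. Against the unsubstituted ring, fluoro in place of hydrogen gives an at least 1.3-fold higher number from compound 1 to compound 3 (0.12 log units; that floor lies within the scatter); that floor cannot separate the two compounds, but the fluorine shows no fall in the number like the one that came with bromo.

This change swaps the halogen and its place together, so these compounds cannot tell the two apart. On these data alone, how a chloro group or an amine on the same ring would read stays open.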